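Hydroxyl epimer of the ester-linked side chain

This account rests on a few compounds, and the source may have more. Where it says the series, first, only, none or still open, it means among the compounds named here.

The series shares the core of compound 1 `CC[C@H](C)C(=O)O[C@H]1CCC=C2C=C[C@H](C)[C@H](CCC(=O)C[C@@H](O)CC(=O)O)[C@H]21`, which in an assay on microsomes from liver for inhibition of 3-hydroxy-3-methylglutaryl-coenzyme A reductase (Rattus norvegicus) (a lower number here means a stronger inhibitor, a higher number a weaker inhibitor), compound 1 gives 32 nM. Compound 2 `CC[C@H](C)C(=O)O[C@H]1CCC=C2C=C[C@H](C)[C@H](COC(=O)CCCC(=O)O)C21` carries an ester-linked chain without the hydroxyl and in this assay compound 2 gives 7100 nM. Compound 3 `CC[C@H](C)C(=O)O[C@H]1CCC=C2C=C[C@H](C)[C@H](COC(=O)C[C@@H](O)CC(=O)O)[C@H]21` keeps the ester linkage but restores the hydroxy acid, and in this assay compound 3 gives 630 nM. Compound 3 thus stands second highest of the three numbers, closer to compound 2, whose value is higher, than to compound 1, whose value is lower; both gaps lie beyond the usual scatter.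

Compound 4 `CC[C@H](C)C(=O)O[C@H]1CCC=C2C=C[C@H](C)[C@H](COC(=O)C[C@H](O)CC(=O)O)[C@H]21` is the next step from compound 3: the two compounds have the same atoms and bonds and differ only in configuration as drawn: 1 of 6 stereo elements differ; a stereocentre at a saturated chain carbon is drawn S in compound 3 and R in compound 4. For the measured compounds named here, no step between measured compounds isolates this change, so the expectation rests on the direction of the series. Compound 1 and compound 3 share the drawn configuration at that chain carbon and both give lower numbers than compound 2, so the inverted configuration of compound 4 is expected to cost activity, with a step well beyond the scatter toward a higher number, estimated as a 7.9-fold higher number from compound 3 to compound 4 (0.90 log units; beyond the scatter). For compound 4 the estimated value in this assay is 5000 nM, within a range of 1500 nM to 20000 nM.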

Compound 4, half-maximal inhibitory concentration: 5000 nM
The estimate for compound 4 equals the measured number at the digits printed; low and high end bracket the measured number.
By their numbers in this assay, from the lowest: compound 1; then compound 3; then compounds 4 and 2 (each within the scatter of the next).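

Working notes on the chain stereocentre. Inverting the saturated chain carbon from S to R gives a 7.9-fold higher number from compound 3 to compound 4 (0.90 log units; beyond the scatter) in this assay, so within the ester-linked series this stereocentre is a position where configuration alone moves the number beyond the scatter. For the compounds shown here, until this pair, no step between measured compounds isolated any single change, and the configuration at this carbon had not been varied at all in the compounds measured. The step can be assigned to this one stereocentre, with no other part of the structure involved, because of a single structural fact: the fact that compounds 3 and 4 differ only in the configuration as drawn.

From the compounds shown here alone, whether the same inversion carries a similar cost on the chain of compound 1, where a ketone stands in place of the ester linkage, remains open, as the present pair speaks only for the ester-linked chain. Also open, going by these compounds, is whether an amide linkage in place of the ester, or a longer chain ending in the same hydroxy acid, would keep this dependence on configuration in this assay.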